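Sulfonamide to Amide Linker: An Untested Change

The compounds below may be only part of what the source reports. "The series", "measured", "known", "first", "only" and "open" are said of these compounds alone.

Compound 1 `CN(C)C(=O)c1cc2cnc(Nc3ccc(S(=O)(=O)NCCCCN=C=S)cc3)nc2n1C1CCCC1` gives 39.4% in a functional assay on A549 cells (Homo sapiens) for inhibition, read by CCK-8 assay, with a stated time of 72 h, tested at 1 uM; on this read-out lower numbers stand for a weaker effect and higher numbers for a stronger effect at the one concentration tested.
Compound 2 `CN(C)C(=O)c1cc2cnc(Nc3ccc(S(=O)(=O)NCCCCCCCN=C=S)cc3)nc2n1C1CCCC1` gives 32.6% in this assay.

Compound 1 has the higher of the two numbers, but the gap to compound 2, a number 6.8 percentage points lower from compound 1 to compound 2 (within the scatter), lies within the scatter. Compound 3 `CN(C)C(=O)c1cc2cnc(Nc3ccc(NC(=O)CCCCCN=C=S)cc3)nc2n1C1CCCC1` differs from compound 1 by a group of 11 heavy atoms (7 carbon, 2 nitrogen, 1 oxygen, 1 sulfur; no ring) in place of a group of 11 heavy atoms (5 carbon, 2 nitrogen, 2 oxygen, 2 sulfur; no ring), on an aromatic carbon. Among the compounds with values here, the one measured step extended the chain beyond the sulfonamide nitrogen and left the read-out essentially unchanged; no measured step touches the linker itself, so that part of the change has no guide. The step of a number 4.4 percentage points lower from compound 1 to compound 3 (within the scatter) is therefore expected to stay within the scatter. Compound 3 is estimated at 35%, within 15% to 55%.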

Compound 3, a percentage reported as inhibition, at one concentration (the size of the read-out at that concentration, not a potency): 56.1%
Estimate against measurement, compound 3: 21.1 percentage points below; measured number outside the range, above it.
By their numbers in this assay, from the lowest: compounds 2 and 1 (each within the scatter of the next); then compound 3.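

Where lengthening the chain in the earlier pair stayed within the scatter, replacing the whole group on this aromatic carbon does move the read-out in this assay with a number 16.7 percentage points higher from compound 1 to compound 3 (beyond the scatter) as the step. This position therefore responds to change, and a sulfonamide linker is not needed to keep the effect at this one concentration. Nothing available explains the gain.

The linker and the chain differ together here, so their separate contributions stay unresolved. On these data alone, how a longer chain on the carbonyl linker, or an amine at the chain end, would read remains open.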